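Cyclopropyl in place of isobutyl: expectation for compound 4

A few compounds are considered here, and "the series" means these few. Any claim that something is new, unique, unknown or untested is made for them only; others in the source may bear on it.

Three measured compounds share one core. In an assay on isolated protein for inhibition of aldehyde dehydrogenase 1A1 (Homo sapiens), read by spectrophotometry, tested at 10 uM (a higher number here means more inhibition at the concentration tested (going by the name of the read-out), a lower number less inhibition), compound 1 `O=C(C1CC1)N1CCN(Cc2nc3ccccc3n2Cc2ccccc2C(F)(F)F)CC1` gives 56.3% and compound 2 `O=C(C1CC1)N1CCN(Cc2nc3ccccc3n2Cc2ccccc2F)CC1` gives 40.7%, with a number 15.6 percentage points lower from compound 1 to compound 2 (beyond the scatter). Compound 3 `CC(C)CCn1c(CN2CCN(C(=O)C3CC3)CC2)nc2ccccc21` stands highest of the three at 70%, above both through a number 13.7 percentage points higher from compound 1 to compound 3 (beyond the scatter) and a number 29.3 percentage points higher from compound 2 to compound 3 (beyond the scatter). Compound 4 `O=C(C1CC1)N1CCN(Cc2nc3ccccc3n2CC2CC2)CC1` differs from compound 3 by cyclopropyl in place of isobutyl on a saturated chain carbon bound to an aromatic nitrogen. Going by the values given here, the two steps that bear on it both swap an aryl for isobutyl and raise inhibition modestly; no measured step compares isobutyl with another alkyl, so this one is read as the smaller move from the group with the higher number. Compound 4 is expected to give 60%, between 42% and 78%, a change of a number 10 percentage points lower from compound 3 to compound 4 (within the scatter) that is likely within the scatter.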

Compound 4, a percentage reported as inhibition, at one concentration (the size of the read-out at that concentration, not a potency): 21.2%
Beside the measured number, compound 4's estimate is 38.8 percentage points above it, outside the stated range (below it).
By their numbers in this assay, from the lowest: compound 4; then compound 2; then compound 1; then compound 3.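

At this position, on a saturated chain carbon bound to an aromatic nitrogen, two alkyl groups part widely in this assay, with a number 48.8 percentage points lower from compound 3 to compound 4 (beyond the scatter) for this change. Cyclopropyl also lies under both aryl groups, with a number 19.5 percentage points lower from compound 2 to compound 4 (beyond the scatter) and a number 35.1 percentage points lower from compound 1 to compound 4 (beyond the scatter), so alkyl over aryl holds for compound 3 and is reversed by compound 4. No measurement at hand accounts for the drop.

On these data alone, whether the drop follows the ring or the lost carbon stays open. A cyclobutyl group or a straight butyl chain here would help separate the two.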